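Aryl change on an aromatic nitrogen in the series

A few compounds are considered here, and "the series" means these few. Any claim that something is new, unique, unknown or untested is made for them only; others in the source may bear on it.

compound 1 `N#CC1=C(N)Oc2c(N)cc3nc4ccccc4nc3c2C12C(=O)N(Cc1cnnn1-c1cccc(C(F)(F)F)c1)c1ccccc12`: 31600 nM
compound 2 `CCOc1ccccc1-n1nncc1CN1C(=O)C2(C(C#N)=C(N)Oc3c(N)cc4nc5ccccc5nc4c32)c2ccccc21`: > 50000 nM, a limit of the assay

In a functional assay on MCF7 cells (Homo sapiens) for antiproliferative activity, read by MTT assay, with a stated time of 48 h (on this read-out higher numbers stand for weaker inhibition and lower numbers for stronger inhibition), compound 1 gives 31600 nM. For compound 2 this assay returns only a limit, > 50000 nM, and this is where compound 2 stands (the limit of > 50000 nM in this assay, at which 1 of the 2 values shown sits). Going by the values given here, the one measured step, an at least 1.5-fold higher number from compound 1 to compound 2 (0.19 log units; that floor lies within the scatter), ran toward that limit. Compound 3 `Cc1ccc(-n2nncc2CN2C(=O)C3(C(C#N)=C(N)Oc4c(N)cc5nc6ccccc6nc5c43)c3ccccc32)cc1Cl` differs from compound 2 by 3-chloro-4-methylphenyl in place of 2-ethoxyphenyl on an aromatic nitrogen. Among the compounds with values here, no measured step covers this exchange, so the direction is open and the estimated step of an at least 1.2-fold lower number from compound 2 to compound 3 (0.09 log units; that floor lies within the scatter) is small with wide uncertainty. Compound 3 is expected at 40000 nM, in the range 12000 nM to 120000 nM.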

Compound 3, half-maximal inhibitory concentration: > 50000 nM
Compound 3 was reported as a limit; the forecaster's own chance of this, stated with the estimate: 50%; middle value at least 1.2-fold (0.09 log units) from the limit.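

In this assay compound 3 also returns only a limit, so a second replacement of 3-(trifluoromethyl)phenyl on the aromatic nitrogen, here by 3-chloro-4-methylphenyl, again yields no numerical value. Going by these compounds alone, the one readable step is an at least 1.5-fold higher number from compound 1 to compound 3 (0.19 log units; that floor lies within the scatter), so no real loss against compound 1 is established, and the step between compound 2 and compound 3 cannot be read. Among the aryl groups at this position, only compound 1 gives a number, and the read-out now gathers at one end: the limit of > 50000 nM in this assay, at which 2 of the 3 values shown sit.

On these data alone, whether an unsubstituted phenyl, or a phenyl carrying an amine or a carboxylic acid, would give a value clear of the limit stays open. As far as these compounds go, how compound 2 and compound 3 truly rank also remains unknown.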